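A few compounds are considered here, and "the series" means these few. Any claim that something is new, unique, unknown or untested is made for them only; others in the source may bear on it.

Measured compounds:
compound 1, `Nc1nc(OCC(F)(F)F)c2ncn(/C=C3/CC3(CO)CO)c2n1` — > 20000 nM
compound 2, `CC(C)CSc1nc(N)nc2c1ncn2/C=C1/CC1(CO)CO` — 60000 nM
compound 3, `CCOc1nc(N)nc2c1ncn2/C=C1/CC1(CO)CO` — > 20000 nM

In an ADME assay on CCRF-HSB-2 cells (Homo sapiens) for cytotoxicity, with a stated time of 7 days (on this read-out higher numbers stand for lower toxicity in this test and lower numbers for higher toxicity in this test), compound 3 gives > 20000 nM, which is a limit of the assay and not a number. Compound 1 also reaches only a limit, > 20000 nM. Compound 2 gives 60000 nM. Two of the three values sit at the same limit, (the limit of > 20000 nM in this assay, at which 2 of the 3 values shown sit), so the step that the two limits leave unreadable from compound 1 to compound 3 and the step that the limit leaves unreadable from compound 2 to compound 3 cannot be read in size, and the step that the limit leaves unreadable from compound 1 to compound 2 is unreadable as well.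

Compound 4, `Nc1nc(NC2CCCC2)c2ncn(/C=C3/CC3(CO)CO)c2n1`, differs from compound 3 in one place: cyclopentylamino in place of ethoxy on an aromatic carbon. Going by the values given here, the only steps that touch the same aromatic carbon are the two unreadable ones, so no direction beyond the scatter can be drawn from them; the expectation is that compound 4 also shows little toxicity in this assay. Compound 4 is therefore estimated at 40000 nM, with a range from 15000 nM to 120000 nM. The step that the limit leaves unreadable from compound 3 to compound 4 that this estimate implies is expected to be unreadable against a limit.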

Compound 4, half-maximal cytotoxic concentration: > 20000 nM
Compound 4: only a limit was reported; the forecaster's own chance of this, stated with the estimate: 60%; the middle value lies beyond the limit too.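

Compound 4 gives > 20000 nM in this assay, which is a limit and not a number. No new step from compound 4 to compound 1, compound 2 or compound 3 can be read: the limit of > 20000 nM in this assay, at which 3 of the 4 values shown sit.

The compounds shown leave open whether the group on this aromatic carbon changes the read-out in this assay at all.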